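Fluoromethyl in Place of Methoxymethyl on a Bisphenol Scaffold

The source may report more compounds than this note shows. Statements on the series, on what has been measured and on what is new or still open speak of the compounds shown alone.

Compound 1 `COc1cc(C(c2ccc(O)c(OC)c2)[C@H](C)[C@@H](C)CF)ccc1O` gives 34000 nM in a functional assay on HeLa cells (Homo sapiens) for cytotoxicity, read by WST assay, with a stated time of 48 h; on this read-out lower numbers stand for stronger inhibition and higher numbers for weaker inhibition. For compound 2 `COc1cc(C(c2ccc(O)c(OC)c2)[C@H](CO)C(C)C)ccc1O` the result in this assay is a limit, > 100000 nM. Compound 3 `COC[C@H](C)[C@H](C)C(c1ccc(O)c(OC)c1)c1ccc(O)c(OC)c1` gives 72000 nM in this assay.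

Of the two numbers, compound 3 stands highest, with a 2.1-fold higher number from compound 1 to compound 3 (0.33 log units; beyond the scatter). Compound 2 sits at a limit (the limit of > 100000 nM in this assay, at which 1 of the 3 values shown sits), and an at least 1.3-fold lower number from compound 2 to compound 3 (0.14 log units; that floor lies within the scatter). Compound 4 `COc1cc(C(c2ccc(O)c(OC)c2)[C@@H](CF)C(C)C)ccc1O` differs from compound 3 by 1-(fluoromethyl)-2-methylpropyl in place of 2-(methoxymethyl)-1-methylpropyl on a saturated chain carbon bound to two aromatic carbons. The step that bears on it is an at least 2.9-fold higher number from compound 1 to compound 2 (0.46 log units; beyond the scatter), where a hydroxymethyl replaced a fluoromethyl and the number rose. The present change runs the other way, toward a fluoromethyl chain, so a modest fall in the number, or none beyond the scatter, is expected in this assay. Compound 4 is estimated at 50000 nM, within 20000 nM to 120000 nM. This estimate means an expected 1.4-fold lower number from compound 3 to compound 4 (0.16 log units; within the scatter).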

Compound 4, half-maximal inhibitory concentration: 41000 nM
Beside the measured number, compound 4's estimate is 1.2-fold (0.09 log units) above it; the range from low to high includes it.
By their numbers in this assay, from the lowest: compounds 1, 4 and 3 (each within the scatter of the next, the first and the last beyond it). At a limit, above all of these: compound 2.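

In this assay the two fluoromethyl chains do not separate, with a 1.2-fold higher number from compound 1 to compound 4 (0.08 log units; within the scatter), and the fluoromethyl chain does not separate from the methoxymethyl chain either, with a 1.8-fold lower number from compound 3 to compound 4 (0.24 log units; within the scatter). Only the exchange of the hydroxymethyl chain for the fluoromethyl chain of the same shape gives a step beyond the scatter, with an at least 2.4-fold lower number from compound 2 to compound 4 (0.38 log units; beyond the scatter). Compound 2 gives a limit rather than a number: the limit of > 100000 nM in this assay, at which 1 of the 4 values shown sits.

The compounds shown leave open how an amine, a carboxylic acid or a longer chain would read at this place on a saturated chain carbon bound to two aromatic carbons.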